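This account rests on a few compounds, and the source may have more. Where it says the series, first, only, none or still open, it means among the compounds named here.

Two compounds have been measured in a functional assay, with a stated time of 10 min; on this read-out higher numbers stand for weaker inhibition and lower numbers for stronger inhibition:

Compound 1 `CCOC(=O)c1cnn(-c2nc(-c3ccc(OC)cc3)c(C#N)c(=O)n2C)c1N`: 74 ug/mL
Compound 2 `CSc1nc(-c2ccc(N(C)C)cc2)c(C#N)c(=O)n1C`: 84 ug/mL

Compound 1 has the lower of the two numbers, yet compound 2 lies within the usual scatter of it, so the two cannot be told apart on this assay. Compound 3 `CCOC(=O)c1cnn(-c2nc(-c3ccccc3F)c(C#N)c(=O)n2C)c1N` differs from compound 1 in one place: 2-fluorophenyl in place of 4-methoxyphenyl on an aromatic carbon. Going by the values given here, no measured pair shows this change, so nothing tells how far it moves the number. With no shown step to rest on, the expected step of a 1.2-fold higher number from compound 1 to compound 3 (0.09 log units; within the scatter) is none beyond the scatter. Compound 3 is therefore expected to give about 90 ug/mL, between 40 ug/mL and 200 ug/mL.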

Compound 3, half-maximal inhibitory concentration: 86 ug/mL
Compound 3: the middle estimate sits 1.0-fold (0.02 log units) above what was measured; the measured number falls inside the stated range.
By their numbers in this assay, from the lowest: compounds 1, 2 and 3 (each within the scatter of the next).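

In this assay, going by these compounds alone, putting 2-fluorophenyl in place of 4-methoxyphenyl on this aromatic carbon gives a 1.2-fold higher number from compound 1 to compound 3 (0.07 log units; within the scatter) and offers the first direct comparison at this position. The two groups therefore cannot be told apart here, even though the hydrogen-bond acceptor counted on 4-methoxyphenyl is gone. Nothing available explains this result. As far as these compounds go, it remains open whether a carboxylic acid, an amine or a longer chain at this position would also leave the number unchanged. A plain phenyl or 4-fluorophenyl could also help separate the effects of group identity and placement.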